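A few compounds are considered here, and "the series" means these few. Any claim that something is new, unique, unknown or untested is made for them only; others in the source may bear on it.

Measured compounds, with their results in an ADME assay on Vero cells (Chlorocebus sabaeus) for cytotoxicity, read by MTT assay, with a stated time of 72 h; a lower number here means that less compound is tolerated, a higher number that more compound is tolerated:

compound 1, `C[C@]1(CN2CCc3nc(C(F)(F)F)ccc3C2)Cn2cc([N+](=O)[O-])nc2O1` — "not determined" (no result reported)
compound 2, `C[C@]1(CN2CCc3nc(C4CC4)ccc3C2)Cn2cc([N+](=O)[O-])nc2O1` — "not determined" (no result reported)
compound 3, `C[C@]1(CN2CCc3nc(-c4ccc(F)c(F)c4)ccc3C2)Cn2cc([N+](=O)[O-])nc2O1` — > 32 ug/mL

Of the three compounds that share this core, only compound 3 has a reported outcome in this assay, and even that outcome is a limit of the assay rather than a number: compound 3 gives > 32 ug/mL. It therefore stands at the limit of > 32 ug/mL in this assay, at which 1 of the 3 values shown sits, and compound 1 and compound 2 give no figure at all, so nothing can be said about how compound 3 compares with them.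

Compound 4, `C[C@]1(CN2CCc3nc(-c4ccc(F)c(Cl)c4)ccc3C2)Cn2cc([N+](=O)[O-])nc2O1`, is the compound still to be tested. It differs from compound 3 by chloro in place of fluoro on an aromatic carbon. Among the measured compounds shown here, no step between two measured compounds is available for this kind of change, so the expectation rests on compound 3 alone. Because compound 3 sits at the limit of > 32 ug/mL in this assay, at which 1 of the 3 values shown sits, the step from compound 3 to compound 4 is expected to be none beyond the usual scatter, that is a number no higher from compound 3 to compound 4 (the limit leaves the size open). On that basis compound 4 is estimated to give 32 ug/mL in this assay, with a range from 16 ug/mL to 64 ug/mL, and most likely it will again be reported only as a limit.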

Compound 4, half-maximal cytotoxic concentration: > 32 ug/mL
Compound 4 ended at the assay's limit (the forecaster's own chance of this, stated with the estimate: 75%); the middle value sits exactly at the limit.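

Among the compounds shown here, compound 3 and compound 4 both end at the same limit in this assay, so no step between them can be read, and the change from fluoro to chloro shows no size: the limit of > 32 ug/mL in this assay, at which 2 of the 4 values shown sit. The compounds shown leave open how far either compound lies past that limit, and where compound 1 and compound 2 stand in this assay.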